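Chloro to Bromo on the Benzyl Group: Expected Outcome

A few compounds are considered here, and "the series" means these few. Any claim that something is new, unique, unknown or untested is made for them only; others in the source may bear on it.

Measured compounds:
compound 1 `O=c1ccoc2cc(OCc3cn(Cc4cccc([N+](=O)[O-])c4)nn3)ccc12` — 9450 nM
compound 2 `O=c1ccoc2cc(OCc3cn(Cc4ccccc4Cl)nn3)ccc12` — > 100000 nM

Both compounds share the same core and differ only in the group on the saturated chain carbon bound to an aromatic nitrogen. In a functional assay on A549 cells (Homo sapiens) for cytotoxicity, read by MTT assay, with a stated time of 48 h (on this read-out lower numbers stand for stronger inhibition and higher numbers for weaker inhibition), compound 1 gives 9450 nM. In this assay compound 2 gives > 100000 nM, which is a limit of the assay rather than a number. Compound 2 thus stands at the limit of > 100000 nM in this assay, at which 1 of the 2 values shown sits. Going by the values given here, the single measured step, an at least 10-fold higher number from compound 1 to compound 2 (1.02 log units; beyond the scatter), covers the exchange of one whole aryl group for another and says nothing directly about a swap of one halogen for another.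

Compound 3 `O=c1ccoc2cc(OCc3cn(Cc4ccccc4Br)nn3)ccc12` is not yet measured. It differs from compound 2 by bromo in place of chloro on an aromatic carbon. Among the compounds with values here, no measured step bears on this particular exchange, so the expectation rests only on where compound 2 already stands. The estimated step of a number no higher from compound 2 to compound 3 (the limit leaves the size open) is therefore no change beyond the scatter, and compound 3 is most likely to return a limit again. The estimate for compound 3 in this assay is 100000 nM, with a range from 30000 nM to 300000 nM.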

Compound 3, half-maximal inhibitory concentration: > 100000 nM
Compound 3 ended at the assay's limit (the forecaster's own chance of this, stated with the estimate: 70%); the middle value lies on the limit itself.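

Exchanging the 3-nitrophenyl group for 2-bromophenyl gives, in this assay, an at least 10-fold higher number from compound 1 to compound 3 (1.02 log units; beyond the scatter), so the large step first seen with 2-chlorophenyl does not depend on chlorine alone. Compound 3 gives > 100000 nM, which is a limit of the assay and not a number. The step from chloro to bromo cannot be read, and all that can be said of this aromatic carbon is that both halogens leave the compound at the limit: the limit of > 100000 nM in this assay, at which 2 of the 3 values shown sit.

The compounds shown leave open whether the nitro group matters in itself or whether the halogen and its place on the ring matter, as each step away from compound 1 changes the group and its place together. Also open, as far as these compounds go, is whether an amine or a carboxylic acid on this aromatic ring would give a number that can be read rather than another limit, which would show how much this part of the molecule can tolerate.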